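The source may report more compounds than this note shows. Statements on the series, on what has been measured and on what is new or still open speak of the compounds shown alone.

Notes on the series. Compound 1 `CO/C(O)=C1\C(C)=NC(C)=C([N+](=O)[O-])C1c1ccncc1` carries a methyl on an oxygen on an unsaturated carbon; in a functional assay (cardiac atrium) for agonist activity, with Cavia porcellus as the target (a higher number here means that more compound is needed for the effect, a lower number that less compound is needed), compound 1 gives 48500 nM. Among the compounds with values here, compound 2 `CC1=NC(C)=C([N+](=O)[O-])C(c2ccncc2)/C1=C(\O)OC1CCCCC1` has cyclohexyl in that place, and in this assay compound 2 gives 4940 nM, the lower of the two numbers measured so far. Within the data shown here, the single measured step, a 9.8-fold lower number from compound 1 to compound 2 (0.99 log units; beyond the scatter), is the only one that bears on the next move. Compound 3 `CC1=NC(C)=C([N+](=O)[O-])C(c2ccncc2)/C1=C(\O)OC1CCCC1` differs from compound 2 by one change: cyclopentyl in place of cyclohexyl on an oxygen on an unsaturated carbon. Read one bond further out, cyclohexyloxy becomes cyclopentyloxy. The measured step shows that going from methyl to cyclohexyl on that oxygen lowered the number substantially; cyclopentyl, with five carbons in a non-aromatic ring, sits far nearer to cyclohexyl than to methyl, so in this assay only a small movement is expected, if any beyond the scatter, and if anything toward a higher number. Compound 3 is therefore expected to give 7000 nM, with a range of 2500 nM to 20000 nM. The expected step is a 1.4-fold higher number from compound 2 to compound 3 (0.15 log units; within the scatter). Among the measured compounds shown here, no measured pair speaks to a five-membered ring here, so the estimate rests on one step alone.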

Compound 3, half-maximal effective concentration: 4250 nM
Estimate against measurement, compound 3: 1.6-fold (0.22 log units) above; the measured number falls inside the stated range.
By their numbers in this assay, from the lowest: compounds 3 and 2 (each within the scatter of the next); then compound 1.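

In this assay, within the data shown here, cyclopentyl in place of cyclohexyl on the oxygen on an unsaturated carbon gives a 1.2-fold lower number from compound 2 to compound 3 (0.07 log units; within the scatter) and so leaves the two rings indistinguishable at this position, which the single earlier step could not show. Cyclopentyl in place of methyl gives an 11-fold lower number from compound 1 to compound 3 (1.06 log units; beyond the scatter) in the same assay, so the separation from the methyl compound, until now seen only with cyclohexyl, also holds for a second non-aromatic ring of carbon only, and compound 3 joins compound 2 on the same side of compound 1. No supporting data accompany these results, and nothing available accounts for the agreement between the two rings or for their separation from methyl.

The compounds shown leave open whether a ring is required on this oxygen at all, a question that an open chain such as isopropyl or n-butyl would address. Also open, from the compounds shown here alone, is how the number responds to a smaller ring such as cyclopropyl, to an aromatic ring such as phenyl, or to a ring carrying a heteroatom such as tetrahydropyranyl on the same oxygen.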